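From 3,5-dimethylphenyl to 4-(dimethylamino)phenyl in compound 4

The source may report more compounds than this note shows. Statements on the series, on what has been measured and on what is new or still open speak of the compounds shown alone.

In a functional assay on CAL-27 cells (Homo sapiens) for cytotoxicity, read by MTT assay, with a stated time of 72 h (on this read-out higher numbers stand for weaker inhibition and lower numbers for stronger inhibition), compound 3 (`Cc1cc(C)cc(C(=O)N(CCCCCC(=O)Nc2ccccc2N)CC(=O)NCc2ccccc2)c1`) gives 13700 nM. This lies within the scatter of compound 2 (`Nc1ccccc1NC(=O)CCCCCN(CC(=O)NCc1ccccc1)C(=O)c1cccc2ccccc12`) at 11000 nM and of compound 1 (`CN(C)c1ccc(C(=O)N(CCCCCC(=O)Nc2cc(F)ccc2N)CC(=O)NCc2ccccc2)cc1`) at 20200 nM. Compound 4 (`CN(C)c1ccc(C(=O)N(CCCCCC(=O)Nc2ccccc2N)CC(=O)NCc2ccccc2)cc1`) remains unmeasured and differs from compound 3 on a carbonyl carbon: 4-(dimethylamino)phenyl in place of 3,5-dimethylphenyl on a carbonyl carbon. Among the measured compounds shown here, the only measured exchange at this carbonyl carbon, a 1.2-fold higher number from compound 2 to compound 3 (0.10 log units; within the scatter), stayed within the scatter. Compound 4 shares its 4-(dimethylamino)phenyl with compound 1, which has an added fluorine and gives 20200 nM. The expected step, a 1.2-fold higher number from compound 3 to compound 4 (0.07 log units; within the scatter), therefore stays within the scatter, with no firm direction. For compound 4 the estimated value is 16000 nM, with an expected range of 8000 nM to 30000 nM.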

Compound 4, half-maximal inhibitory concentration: 16000 nM
Beside the measured number, compound 4's estimate shows no gap at the digits printed, within the range that was stated.
By their numbers in this assay, from the lowest: compounds 2, 3, 4 and 1 (each within the scatter of the next).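

In this assay, 4-(dimethylamino)phenyl on the carbonyl carbon stays within the scatter of both groups seen there before: a 1.2-fold higher number from compound 3 to compound 4 (0.07 log units; within the scatter) and a 1.5-fold higher number from compound 2 to compound 4 (0.16 log units; within the scatter). With compound 4 the fluoro can now be read alone, and hydrogen in its place on the aromatic carbon also stays within the scatter: a 1.3-fold lower number from compound 1 to compound 4 (0.10 log units; within the scatter). Nothing at hand explains these small steps.

As far as these compounds go, whether a cyclohexyl or pyridin-3-yl group on this carbonyl carbon would stay within the same scatter remains open. So does the effect of chloro or methoxy in place of that hydrogen.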